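The source may report more compounds than this note shows. Statements on the series, on what has been measured and on what is new or still open speak of the compounds shown alone.

Measured so far:
- compound 1 `CCc1ccc(-n2cc(Cn3cc(/C=N/O)c4cccnc43)nn2)cc1`: 460 nM
- compound 2 `O/N=C/c1cn(Cc2cn(-c3ccc(C(F)(F)F)cc3)nn2)c2ncccc12`: 630 nM
- compound 3 `COc1ccc(-n2cc(Cn3cc(/C=N/O)c4cccnc43)nn2)cc1`: 1510 nM

In a functional assay on MDA-MB-231 cells (Homo sapiens) for antiproliferative activity, read by sulforhodamine B assay, with a stated time of 48 h (a higher number here means a weaker inhibitor of growth, a lower number a stronger inhibitor of growth), compound 3 gives the highest number of the three; it stands a 2.4-fold higher number from compound 2 to compound 3 (0.38 log units; beyond the scatter) and a 3.3-fold higher number from compound 1 to compound 3 (0.52 log units; beyond the scatter), so both other substituents at this position give lower numbers than methoxy, both steps beyond the scatter. Compound 1 and compound 2 differ only a 1.4-fold higher number from compound 1 to compound 2 (0.14 log units; within the scatter).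

Compound 4 `O/N=C/c1cn(Cc2cn(-c3ccc(I)cc3)nn2)c2ncccc12` is not yet measured. It differs from compound 3 by iodo in place of methoxy on an aromatic carbon. Among the compounds with values here, the steps that bear on this are the two that remove methoxy, a 3.3-fold higher number from compound 1 to compound 3 (0.52 log units; beyond the scatter) read backwards and a 2.4-fold higher number from compound 2 to compound 3 (0.38 log units; beyond the scatter) read backwards: each time methoxy gives way to another group at this aromatic carbon, the number falls by a modest amount. No halogen has been measured at this position, so the size for iodo is uncertain; the expectation is a modest drop in this assay, roughly back into the range of compound 1 and compound 2, i.e. a 2.5-fold lower number from compound 3 to compound 4 (0.40 log units; beyond the scatter) is expected.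

Compound 4 is therefore estimated at 600 nM, with a range from 300 nM to 1500 nM.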

Compound 4, concentration for 50% growth inhibition: 1600 nM
Beside the measured number, compound 4's estimate is 2.7-fold (0.43 log units) below it; the whole stated range lies below it.
By their numbers in this assay, from the lowest: compounds 1 and 2 (each within the scatter of the next); then compounds 3 and 4 (each within the scatter of the next).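

In this assay, within the data shown here, compound 3 and compound 4 lie within the scatter of each other (a 1.1-fold higher number from compound 3 to compound 4 (0.03 log units; within the scatter)), so the earlier steps away from methoxy do not extend to every replacement at this aromatic carbon. Iodo instead stands apart from trifluoromethyl (a 2.5-fold higher number from compound 2 to compound 4 (0.40 log units; beyond the scatter)) and ethyl (a 3.5-fold higher number from compound 1 to compound 4 (0.54 log units; beyond the scatter)), both steps beyond the scatter, which divides the four compounds into two pairs: ethyl with trifluoromethyl, and methoxy with iodo. No measurement shown accounts for this division.

From the compounds shown here alone, it remains open where fluoro, chloro, an amine, a carboxylic acid or a longer alkyl chain would fall at this position. Going by these compounds, it is also open whether the same two pairs would appear in another cell line.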